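The compounds below may be only part of what the source reports. "The series", "measured", "known", "first", "only" and "open" are said of these compounds alone.

Compound 1 `CC(C)CCn1c(Cn2c(=O)n(C(C)C)c3ccccc32)nc2cc(C(C)(C)N)ccc21`: 3270 nM
Compound 2 `CC(C)CCn1c(Cn2c(=O)n(C(C)C)c3ccccc32)nc2cc(CO)ccc21`: 31600 nM

For the measured compounds named here, in an ADME assay on HEp-2 cells (Homo sapiens) for cytotoxicity (a lower number here means that less compound is tolerated, a higher number that more compound is tolerated), compound 2 holds the highest of the two numbers, with compound 1 as its only neighbour. Going by the values given here, the single measured step is a 9.7-fold higher number from compound 1 to compound 2 (0.99 log units; beyond the scatter). Compound 3 `CC(C)CCn1c(Cn2c(=O)n(C(C)C)c3ccccc32)nc2cc(-c3nn[nH]n3)ccc21` differs from compound 2 by 2H-tetrazol-5-yl in place of hydroxymethyl on an aromatic carbon. Among the compounds with values here, no measured step involves a 2H-tetrazol-5-yl group, so that step offers no direct guide; with nothing to point either way, no change beyond the scatter is expected in this assay. Compound 3 is therefore estimated at 30000 nM, within 10000 nM to 100000 nM. The expected step is a 1.1-fold lower number from compound 2 to compound 3 (0.02 log units; within the scatter).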

Compound 3, half-maximal cytotoxic concentration: 2000 nM
Estimate against measurement, compound 3: 15-fold (1.18 log units) above; measured number outside the range, below it.
By their numbers in this assay, from the lowest: compounds 3 and 1 (each within the scatter of the next); then compound 2.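

In this assay, the result shows that the high number of compound 2 does not hold across this position on the six-membered aromatic ring: 2H-tetrazol-5-yl in place of hydroxymethyl gives a 16-fold lower number from compound 2 to compound 3 (1.20 log units; beyond the scatter). Set against 1-amino-1-methylethyl, the same group gives a 1.6-fold lower number from compound 1 to compound 3 (0.21 log units; within the scatter), so two quite different substituents sit together and hydroxymethyl alone stands apart among the three compounds. Nothing available explains this.

On these data alone, it remains open whether a carboxylic acid or an aminomethyl group at this position would fall with compound 2 or with compound 1 and compound 3.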